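The source may hold more compounds than are shown below. What is called first, only, known or untested is meant among the compounds shown, and "the series" means these compounds.

Compound 1 `C[C@H](CC(=O)O)CC(=O)c1c([C@@H](O)CCCCCc2ccccc2)n(C)c2ccc(Cl)cc12` is the strongest of the three compounds measured here. In a functional assay for antagonist activity at Oxoeicosanoid receptor 1 (Homo sapiens), read by fluorescence and calcium flux, with stated times of 2 min and 1 min (on this read-out higher numbers stand for weaker inhibition and lower numbers for stronger inhibition), compound 1 gives 0.38 nM. Its nearest neighbour on this read-out is compound 3 `CC(CC(=O)O)CC(=O)n1c(CCCCCc2ccccc2)cc2ccc(Cl)cc21`, which in this assay gives 2.1 nM, and the furthest is compound 2 `CC(CC(=O)O)CC(=O)n1c(CCCCCCc2ccccc2)cc2ccc(Cl)cc21`, which gives 12 nM. Within the data shown here, the only single-point step among the measured compounds, a 5.7-fold lower number from compound 2 to compound 3 (0.76 log units; beyond the scatter), concerns the length of the chain that carries the phenyl group and not the stereochemistry.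

Compound 4 `C[C@H](CC(=O)O)CC(=O)c1c([C@H](O)CCCCCc2ccccc2)n(C)c2ccc(Cl)cc12` differs from compound 1 only in configuration: the two compounds have the same atoms and bonds and differ only in configuration as drawn: 1 of 2 stereo elements differ; a stereocentre at a saturated chain carbon is drawn S in compound 1 and R in compound 4. The hydroxyl-bearing carbon is therefore drawn with the opposite hand while every atom and bond stays the same.

No measured step bears on a change of configuration, so the size and even the direction of the effect cannot be read from the data shown. Among the measured compounds shown here, the only guidance is that compound 1 sits at the bottom of the range with 0.38 nM, which leaves more room for a higher number than for a lower one. Compound 4 is therefore expected to give a somewhat higher number, 4 nM, within a wide range from 0.4 nM to 40 nM, which corresponds to an expected step of an 11-fold higher number from compound 1 to compound 4 (1.02 log units; beyond the scatter).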

Compound 4, half-maximal inhibitory concentration: 260 nM
For compound 4 the middle estimate is 65-fold (1.81 log units) below the measured one; measured number above the stated range.
By their numbers in this assay, from the lowest: compound 1; then compound 3; then compound 2; then compound 4.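

In this assay, among these compounds, inverting the hydroxyl-bearing carbon gives a 680-fold higher number from compound 1 to compound 4 (2.84 log units; beyond the scatter), a large step that is much bigger than the change seen with chain length, a 5.7-fold lower number from compound 2 to compound 3 (0.76 log units; beyond the scatter), and the first step here that speaks to configuration at all. The whole of this large step can be put down to the hand of that one carbon, since no atom or bond changes and nothing else separates the pair: the fact that compounds 1 and 4 differ only in the configuration as drawn. Among the compounds shown here, this position is therefore far from indifferent to its three-dimensional arrangement: the same atoms give strong or much weaker inhibition, and the form drawn S, as in compound 1, is the one with the lower number.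

The pair cannot say whether the hydroxyl group itself is needed, or whether a methoxy group, a ketone or a plain methylene at this carbon would keep the low number of compound 1 or fall closer to that of compound 4. On these data alone, the other stereocentre, on the methyl-bearing carbon of the acid chain, is drawn the same in both compounds, so how much its hand matters also remains open.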